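A few compounds are considered here, and "the series" means these few. Any claim that something is new, unique, unknown or untested is made for them only; others in the source may bear on it.

In a functional assay on cells (T-cell line, Homo sapiens) for inhibition (a lower number here means a stronger inhibitor, a higher number a weaker inhibitor), compound 1 `COc1ccccc1CCCN1CCC(COC(c2ccccc2)c2ccccc2)CC1` gives 2400 nM. Compound 2 `CCN1CCC(COC(c2ccccc2)c2ccccc2)CC1` gives > 20000 nM, which is a limit of the assay and not a number. Compound 3 `CCCCN1CCC(COC(c2ccccc2)c2ccccc2)CC1` gives 14000 nM, the higher of the two actual numbers. Compound 4 `CCCCCCCN1CCC(COC(c2ccccc2)c2ccccc2)CC1` extends its chain: propyl in place of hydrogen on a saturated chain carbon, four bonds along the chain from an amine nitrogen in a ring, with propyl in place of hydrogen, four bonds along the chain from an amine nitrogen in a ring. Within the data shown here, two measured steps bear on this: an at least 1.4-fold lower number from compound 2 to compound 3 (0.15 log units; that floor lies within the scatter), whose floor lies within the scatter, and a 5.8-fold higher number from compound 1 to compound 3 (0.77 log units; beyond the scatter), which is beyond it. A modest move to a lower number is therefore expected, smaller than that second step. The expected change is a 2.3-fold lower number from compound 3 to compound 4 (0.37 log units; beyond the scatter). For compound 4 the estimated value is 6000 nM, within a range of 1800 nM to 20000 nM.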

Compound 4, half-maximal inhibitory concentration: 500 nM
For compound 4 the middle estimate is 12-fold (1.08 log units) above the measured one; measured number outside the range, below it.
By their numbers in this assay, from the lowest: compound 4; then compound 1; then compound 3. At a limit, above all of these: compound 2.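

In this assay propyl in place of hydrogen, four bonds along the chain from an amine nitrogen in a ring, gives a 28-fold lower number from compound 3 to compound 4 (1.45 log units; beyond the scatter) and so shows a large gain that the shorter chains gave no sign of. Because compound 2 stands at a limit, its step gives only a floor, an at least 40-fold lower number from compound 2 to compound 4 (1.60 log units; beyond the scatter) and not an exact size. The plain chain also beats the chain bearing 2-methoxyphenyl, with a 4.8-fold lower number from compound 1 to compound 4 (0.68 log units; beyond the scatter) and no ring at its end. From the compounds shown here alone, whether a longer chain lowers the number further stays open, as does the effect of an amine at the chain end.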